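The source may hold more compounds than are shown below. What is called first, only, known or untested is meant among the compounds shown, and "the series" means these compounds.

Compound 1 `Cc1ccccc1-c1cc(C(C)(C)C)cc(C(C)C)c1CO` gives in a functional assay on RKE cells for antagonist activity at Vasoactive intestinal polypeptide receptor 1 (Rattus norvegicus), read by HTRF and cAMP accumulation, with stated times of 10 min and 30 min (on this read-out lower numbers stand for stronger inhibition and higher numbers for weaker inhibition), a value of > 50000 nM, which is a limit of the assay and not a number.
Compound 2 `CC(C)c1cc(C(C)(C)C)cc(-c2ccccc2-c2ccccc2)c1CO` gives in this assay a value of 3200 nM.
Compound 3 `COc1ccccc1-c1cc(C(C)(C)C)cc(C(C)C)c1CO` gives in this assay a value of 820 nM.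

Compound 1 therefore stands at the weak end of the three, sitting at the limit of > 50000 nM in this assay, at which 1 of the 3 values shown sits. Phenyl in place of methyl produces an at least 15-fold lower number from compound 1 to compound 2 (1.19 log units; beyond the scatter), methoxy in place of methyl produces an at least 60-fold lower number from compound 1 to compound 3 (1.78 log units; beyond the scatter), and between those two there is a 3.9-fold lower number from compound 2 to compound 3 (0.59 log units; beyond the scatter). Compound 4 `Cc1ccc(-c2cc(C(C)(C)C)cc(C(C)C)c2CO)cc1` differs from compound 1 by 4-methylphenyl in place of 2-methylphenyl on an aromatic carbon. Going by the values given here, no measured step changes the pendant ring itself; both steps from compound 1 replace the group on the shared core. The expectation for compound 4 is thus uncertain, with a real chance that it also sits at the limit. The estimate for compound 4 in this assay is 8000 nM, from 1500 nM to 50000 nM, meaning an expected at least 6.2-fold lower number from compound 1 to compound 4 (0.79 log units; beyond the scatter).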

Compound 4, half-maximal inhibitory concentration: 300 nM
Estimate against measurement, compound 4: 27-fold (1.43 log units) above; the measured number lies below the stated range.
By their numbers in this assay, from the lowest: compound 4; then compound 3; then compound 2. At a limit, above all of these: compound 1.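

In this assay, a change in where the methyl group sits on the pendant ring, with the atoms unchanged, gives an at least 160-fold lower number from compound 1 to compound 4 (2.22 log units; beyond the scatter). The earlier steps shown here exchanged one group for another, whereas this one shows that the arrangement of the same pendant ring at this position, ortho to the hydroxymethyl group, matters on its own. The true size of the step remains unknown, since compound 1 gives only a limit of the assay: the limit of > 50000 nM in this assay, at which 1 of the 4 values shown sits.

The compounds shown leave open whether the methyl group of 4-methylphenyl is itself needed. They also do not show how an amine or a carboxylic acid in its place would compare.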